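Extending the urea of compound 3 in a cell assay

The source may report more compounds than this note shows. Statements on the series, on what has been measured and on what is new or still open speak of the compounds shown alone.

In a functional assay on MIA PaCa-2 cells (Homo sapiens) for inhibition, read by MTT assay, with a stated time of 72 h (on this read-out lower numbers stand for stronger inhibition and higher numbers for weaker inhibition), compound 1 `COc1cc(NC(C)CCCNC(=O)Nc2cccc(F)c2)c2ncccc2c1` gives 22000 nM and compound 2 `COc1cc(NC(C)CCCNC(=O)Nc2ccc(C(F)(F)F)cc2)c2ncccc2c1` gives 8400 nM. Compound 3 `COc1cc(NC(C)CCCNC(=O)Nc2cccc(C(F)(F)F)c2)c2ncccc2c1` gives 17000 nM, with a 1.3-fold lower number from compound 1 to compound 3 (0.11 log units; within the scatter) and a 2.0-fold higher number from compound 2 to compound 3 (0.31 log units; beyond the scatter). Compound 4 `COc1cc(NC(C)CCCNC(=O)NNC(=O)Nc2cccc(Cl)c2)c2ncccc2c1` carries ((3-chlorophenyl)carbamoyl)amino in place of 3-(trifluoromethyl)phenyl on an amide-type nitrogen. The measured steps only exchange aromatic groups, the largest being a 2.6-fold lower number from compound 1 to compound 2 (0.42 log units; beyond the scatter), and none of them tests a change of this kind. Only a small shift is therefore expected in this assay, with no firm direction. The expected change is a 1.2-fold lower number from compound 3 to compound 4 (0.08 log units; within the scatter), which remains an uncertain estimate. For compound 4 the estimated value is 14000 nM, with an expected range from 5000 nM to 40000 nM.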

Compound 4, half-maximal inhibitory concentration: 74000 nM
Estimate against measurement, compound 4: 5.3-fold (0.72 log units) below; measured number outside the range, above it.
By their numbers in this assay, from the lowest: compound 2; then compounds 3 and 1 (each within the scatter of the next); then compound 4.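

Placing ((3-chlorophenyl)carbamoyl)amino on the amide-type nitrogen shifts the number in this assay further than any exchange of aromatic groups did, with a 4.4-fold higher number from compound 3 to compound 4 (0.64 log units; beyond the scatter), an 8.8-fold higher number from compound 2 to compound 4 (0.94 log units; beyond the scatter) and a 3.4-fold higher number from compound 1 to compound 4 (0.53 log units; beyond the scatter). All three steps point towards weaker inhibition, so this position responds to more than the choice of aromatic group. Nothing available here accounts for the shift.

The step changes the aromatic substituent and the chain together, so their shares stay unseparated. On these data alone, a 3-chlorophenyl on the amide-type nitrogen would divide them, and how an amine or a carboxylic acid there would behave remains open.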